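Lengthening a side chain by one carbon in a pyrimidine series

The compounds below may be only part of what the source reports. "The series", "measured", "known", "first", "only" and "open" are said of these compounds alone.

Of the compounds shown here, three sharing one core have been measured in a physicochemical assay for lipophilicity; on this read-out higher numbers stand for higher lipophilicity and lower numbers for lower lipophilicity. Compound 1 `Cc1csc2cc([C@H](C)Nc3ncnc(N)c3C#N)c(-c3cccc(CN(C)CCCCN(C)Cc4ccccc4)c3)c(=O)n12` gives 2.2. Compound 2 `Cc1csc2cc([C@H](C)Nc3ncnc(N)c3C#N)c(-c3cccc(CN4CCC(N(C)CC(C)C)CC4)c3)c(=O)n12` gives 1.7, which places it second highest of the three numbers, with compound 1 above it and compound 3 `Cc1csc2cc([C@H](C)Nc3ncnc(N)c3C#N)c(-c3cccc(CC4CCN(C(C)C)CC4)c3)c(=O)n12`, which gives 1.1, below it. Going by the values given here, the step of a number 0.60 log units lower from compound 2 to compound 3 (beyond the scatter) is the only change between measured compounds that differs in one place, and it touches the same part of the molecule as the new compound does.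

Compound 4 `Cc1csc2cc([C@H](C)Nc3ncnc(N)c3C#N)c(-c3cccc(CN4CCC(CN(C)CC(C)C)CC4)c3)c(=O)n12` is not yet measured. It differs from compound 2 by (isobutyl(methyl)amino)methyl in place of isobutyl(methyl)amino on a saturated ring carbon; the change adds one carbon in the link between the ring and the amine. The measured step from compound 2 to compound 3 is a different swap, so it only loosely guides what to expect here. With the extra carbon and the same count of donors and acceptors, compound 4 is expected to sit slightly above compound 2, a rise of a number 0.30 log units higher from compound 2 to compound 4 (within the scatter) that may not clear the scatter. Compound 4 is therefore estimated at 2 in this assay, with a likely range from 1.6 to 2.4.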

Compound 4, distribution coefficient: 2.1
Compound 4: the middle estimate sits 0.10 log units below what was measured; low and high end bracket the measured number.
By their numbers in this assay, from the lowest: compound 3; then compound 2; then compounds 4 and 1 (each within the scatter of the next).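

In this assay, going by these compounds alone, the step from the earlier compounds to this one isolates a smaller change: the isobutyl(methyl)amino group stays in compound 4, and only a methyl link is added on the saturated ring carbon, which gives a number 0.40 log units higher from compound 2 to compound 4 (beyond the scatter) with no change in the counts of hydrogen-bond donors and acceptors. The earlier step from compound 2 to compound 3 replaced a whole group, so it could not show that this position responds to so small an edit; here, a difference beyond the scatter appears even though the amine itself is retained. Nothing available here accounts for the size or direction of this rise.

A single added link cannot show whether the number would keep moving with a longer chain, such as (isobutyl(methyl)amino)ethyl, or would level off. It also leaves open whether the same methyl link would produce a similar step with a different amine on its end, such as dimethylamino or a morpholine ring, in place of isobutyl(methyl)amino.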